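Varying the ester side chain in a dihydropyridine series

A few compounds are considered here, and "the series" means these few. Any claim that something is new, unique, unknown or untested is made for them only; others in the source may bear on it.

Of the compounds shown here, three of a shared core have been measured in a functional assay on HEK293 cells for antagonist activity at Voltage-dependent L-type calcium channel subunit alpha-1C (Oryctolagus cuniculus), read by FLIPR; a higher number here means a weaker inhibitor, a lower number a stronger inhibitor. Compound 1 `CCOC(=O)C1=C(C)NC(COC(C)=O)=C(C(=O)OCC)C1c1cccc([N+](=O)[O-])c1` gives 10 nM. Compound 3 `CCOC(=O)C1=C(C)NC(C)=C(C(=O)OCCOC)C1c1cccc([N+](=O)[O-])c1` gives 16 nM. Compound 2 `C=C(C)CCOC(=O)C1=C(C)NC(C)=C(C(=O)OC)C1c1cccc([N+](=O)[O-])c1` gives 23 nM, the highest of the three numbers; its gap to compound 3 lies within the scatter, while its gap to compound 1 lies beyond it, so compound 1 inhibits more strongly than compound 2 on these numbers.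

Compound 4 `COC(=O)C1=C(C)NC(C)=C(C(=O)OCC(C)[N+](=O)[O-])C1c1cccc([N+](=O)[O-])c1` has not yet been measured. It differs from compound 2 by 1-nitroethyl in place of 2-methylprop-2-en-1-yl on a saturated chain carbon bound to an oxygen next to a carbonyl group. For the measured compounds named here, no pair of measured compounds shows this kind of change, so the expected size of the step cannot be read from a measured step; the three numbers known so far sit close together, and the change alters only the ester side chain. The step from compound 2 to compound 4 in this assay is therefore expected to be small, a 1.3-fold higher number from compound 2 to compound 4 (0.12 log units; within the scatter), with no clear direction beyond the scatter. Compound 4 is estimated at 30 nM, within a range from 8 nM to 120 nM.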

Compound 4, half-maximal inhibitory concentration: 108 nM
Compound 4: middle estimate off by 3.6-fold (0.56 log units), on the low side; the range from low to high includes it.
By their numbers in this assay, from the lowest: compounds 1, 3 and 2 (each within the scatter of the next, the first and the last beyond it); then compound 4.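

For the compounds shown here, this is the first step in the set that changes one place only, so it is the first direct reading of the ester side chain in this assay. Putting 1-nitroethyl in place of 2-methylprop-2-en-1-yl on a saturated chain carbon bound to an oxygen next to a carbonyl group gives a 4.7-fold higher number from compound 2 to compound 4 (0.67 log units; beyond the scatter) and so a weaker inhibitor, which shows that this position does not tolerate every side chain equally. Nothing at hand accounts for the loss.

A single pair cannot separate the effect of adding the nitro group from that of losing the alkene-bearing chain. It also leaves open whether a saturated chain of similar length, an amine or a carboxylic acid at this place would stay close to compound 2 or follow compound 4.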